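The compounds below may be only part of what the source reports. "The series", "measured", "known", "first", "only" and "open" are said of these compounds alone.

Compound 1 `O=c1c(-c2ccc(O)cc2)coc2cc(OCCOCCOCCO)ccc12` and compound 2 `CCCCCCC(Oc1ccc2c(=O)c(-c3ccc(O)cc3)coc2c1)C(=O)OCC` share one core and differ only in the group carried on the aromatic ether oxygen. In an assay (Cricetulus griseus) for inhibition of aldehyde dehydrogenase, mitochondrial (Homo sapiens) (on this read-out lower numbers stand for stronger inhibition and higher numbers for weaker inhibition), compound 1 gives 40 nM, whereas in this assay compound 2 gives 7200 nM. Compound 1 therefore stands lowest of the two numbers, and the gap up to compound 2 lies well beyond the scatter. Compound 3 `CC(C)Oc1ccc2c(=O)c(-c3ccc(O)cc3)coc2c1` carries isopropyl in place of 2-(2-(2-hydroxyethoxy)ethoxy)ethyl on an oxygen on an aromatic ring. Going by the values given here, no measured pair covers this change; the expected step of a 3.8-fold higher number from compound 1 to compound 3 (0.57 log units; beyond the scatter) is a moderate loss, beyond the scatter. Compound 3 is estimated at 150 nM, within 30 nM to 800 nM.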

Compound 3, half-maximal inhibitory concentration: 80 nM
Estimate against measurement, compound 3: 1.9-fold (0.27 log units) above; the range from low to high includes it.
By their numbers in this assay, from the lowest: compounds 1 and 3 (each within the scatter of the next); then compound 2.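

In this assay, isopropyl in place of 2-(2-(2-hydroxyethoxy)ethoxy)ethyl on an oxygen on an aromatic ring gives a 2.0-fold higher number from compound 1 to compound 3 (0.30 log units; within the scatter). At this position, then, a small group without hydrogen-bond donors or acceptors reads the same as the longer chain that carries them, so neither the chain nor its oxygens are needed to hold the number. No measurement available explains this result. Which part of the larger group on compound 2 goes with its much higher number stays open. Also open, from the compounds shown here alone, is whether an amine or a carboxylic acid on this oxygen would stay level with compound 1 and compound 3.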